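Swapping a Urea for an Aryl Amine on the Shared Core

The source may report more compounds than this note shows. Statements on the series, on what has been measured and on what is new or still open speak of the compounds shown alone.

Compound 1, `C=CCNC(=O)Nc1cncc2nc(-c3ccccc3)cnc12`: in an assay on Sf21 cells for inhibition of high affinity nerve growth factor receptor (Homo sapiens), read by AlphaScreen, with a stated time of 1 h (a higher number here means a weaker inhibitor, a lower number a stronger inhibitor), compound 1 gives > 100000 nM, a limit of the assay.
Compound 2, `Fc1ccc(Nc2cncc3nc(-c4ccccc4)cnc23)cc1Cl`: compound 2 gives > 100000 nM, also a limit.
Compound 3, `CCNC(=O)Nc1nccc2nc(-c3ccccc3)cnc12`: compound 3 gives > 100000 nM, again a limit.

Compound 3 thus stands at the limit of > 100000 nM in this assay, at which 3 of the 3 values shown sit, and nothing separates it from the other two. Compound 4, `COc1ccccc1Nc1nccc2nc(-c3ccccc3)cnc12`, differs from it by 2-methoxyphenyl in place of ethylcarbamoyl on a nitrogen on an aromatic ring. Among the compounds with values here, the only measured step, a step that the two limits leave unreadable from compound 1 to compound 2, likewise puts an aryl group in place of a urea on such a nitrogen, but on a core that is not the shared core of compound 3 and compound 4, and both of its ends are limits, so its size cannot be read. Within the data shown here, no measured step therefore shows what to expect in this assay. With every value at the limit, compound 4 is expected to stay there as well, a number no higher from compound 3 to compound 4 (the limit leaves the size open) amounting to no readable change. Compound 4 is estimated at 100000 nM, between 20000 nM and 500000 nM.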

Compound 4, half-maximal inhibitory concentration: > 100000 nM
Compound 4 was reported as a limit; the forecaster's own chance of this, stated with the estimate: 75%; the middle value sits exactly at the limit.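

No size can be read for the step between compound 3 and compound 4, since both values are limits: the limit of > 100000 nM in this assay, at which 4 of the 4 values shown sit.

Which change on the shared core, if any, would give a readable value in this assay stays open among the compounds shown.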